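Fluoro for hydrogen on two hydrazinyl pyrimidine cores

The source may report more compounds than this note shows. Statements on the series, on what has been measured and on what is new or still open speak of the compounds shown alone.

Compound 2 `Oc1ccccc1/C=N/Nc1ncccn1` gives 32% in an assay on isolated protein for inhibition of lysine-specific demethylase 5A (Homo sapiens), read by AlphaLISA, with stated times of 15 min and 1 h, tested at 10 uM; a higher number here means more inhibition at the concentration tested (going by the name of the read-out), a lower number less inhibition. Compound 1 `Oc1ccccc1/C=N/Nc1ncc(F)cn1` differs by fluoro in place of hydrogen on an aromatic carbon and gives -13% in this assay, so the change made a step of a number 45 percentage points lower from compound 2 to compound 1 (beyond the scatter). Compound 3 `NNc1nccc(Oc2ccccc2)n1` has a different core; the difference between the two cores is not broken down here. In this assay compound 3 gives -72%, the lowest of the three numbers. Compound 4 `NNc1nccc(Oc2ccc(F)cc2)n1` differs from compound 3 by fluoro in place of hydrogen on an aromatic carbon. This is the same kind of change as from compound 2 to compound 1, but the place differs: there the fluoro sat on a ring with 2 nitrogen, two atoms from the ring nitrogen, para to a large group; here it sits on a ring of carbon only, para to a group of 9 heavy atoms. Because compound 3 already stands at -72%, the step is expected to be small, about a number 3 percentage points lower from compound 3 to compound 4 (within the scatter). Compound 4 is estimated at -75%, within -110% to -40%.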

Compound 4, a percentage reported as inhibition, at one concentration (the size of the read-out at that concentration, not a potency): -50%
The estimate for compound 4 lay 25 percentage points below the measured number, and the stated range covers the measured number.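

In this assay the swap of hydrogen for fluoro gave a number 22 percentage points higher from compound 3 to compound 4 (beyond the scatter), so it did not repeat its result on the core of compound 2, and the two steps point in opposite directions: the same change on two cores in this assay, a number 45 percentage points lower (beyond the scatter) from compound 2 to compound 1 and a number 22 percentage points higher (beyond the scatter) from compound 3 to compound 4, 67 percentage points apart, beyond the scatter of two such steps. Among these compounds, then, the result of this change does not carry from one core to the other. This does not show why, since the fluoro also sits in a different place in each pair, so core and place cannot be told apart, and two pairs set no rule for other cores.

From the compounds shown here alone, whether an amine or a methoxy group in place of the fluoro of compound 4 would move the number the same way remains open. So does the result of fluoro elsewhere on its ring of carbon only.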